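The source may hold more compounds than are shown below. What is called first, only, known or untested is meant among the compounds shown, and "the series" means these compounds.

Measured compounds:
- compound 1 `CC(C)(C)n1cc2c(n1)C(=O)CC1(CCN(C(=O)c3cc(-c4ccccc4Cl)nc4ccccc34)CC1)O2`: 2180 nM
- compound 2 `CC(C)(C)n1cc2c(n1)C(=O)CC1(CCN(C(=O)c3cc(N4CCNCC4)nc4ccccc34)CC1)O2`: > 10000 nM

Among the measured compounds shown here, in a functional assay on A549 cells (Homo sapiens) for inhibition, read by MTT assay, with a stated time of 72 h (on this read-out lower numbers stand for stronger inhibition and higher numbers for weaker inhibition), compound 1 gives 2180 nM, the only number reported among the two measured compounds. For compound 2 the assay reports a limit rather than a number, > 10000 nM. For the measured compounds named here, the one measured step, an at least 4.5-fold higher number from compound 1 to compound 2 (0.66 log units; beyond the scatter), shows that replacing the 2-chlorophenyl on the aromatic carbon is not tolerated, and the other value sits at the limit of > 10000 nM in this assay, at which 1 of the 2 values shown sits.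

Compound 3 `CC(C)Oc1cc(C(=O)N2CCC3(CC2)CC(=O)c2nn(C(C)(C)C)cc2O3)c2ccccc2n1` has not yet been measured. It differs from compound 1 by isopropoxy in place of 2-chlorophenyl on an aromatic carbon. Going by the values given here, the only measured step that bears on this change is an at least 4.5-fold higher number from compound 1 to compound 2 (0.66 log units; beyond the scatter), which also removes the 2-chlorophenyl from the same aromatic carbon; there the number rose to a limit. Isopropoxy is a different replacement from piperazin-1-yl, so the size of the step for compound 3 is uncertain, but the direction is expected to be the same: a higher number, weaker inhibition. Compound 3 is therefore estimated to give 7000 nM in this assay, within 2200 nM to 20000 nM, and the expected step of a 3.2-fold higher number from compound 1 to compound 3 (0.51 log units; beyond the scatter) is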

Compound 3, half-maximal inhibitory concentration: > 10000 nM
Compound 3 was reported as a limit; the forecaster's own chance of this, stated with the estimate: 40%; at least 1.4-fold (0.15 log units) between middle value and limit.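

In this assay, the change to isopropoxy gives an at least 4.5-fold higher number from compound 1 to compound 3 (0.66 log units; beyond the scatter), so a second replacement of the 2-chlorophenyl on this aromatic carbon, next to the ring nitrogen, also gives weaker inhibition. Compound 2 had shown this for piperazin-1-yl alone, whereas isopropoxy has no ring and brings in oxygen, which means that the result now holds for two quite different groups at this position. Among the compounds shown, only compound 1 keeps a measurable number, and the step between compound 2 and compound 3 cannot be read, leaving the two replacements unranked; both are limits of the assay, not numbers: the limit of > 10000 nM in this assay, at which 2 of the 3 values shown sit.

The compounds shown leave open whether the chlorine or the aromatic ring of the 2-chlorophenyl is what matters, which a plain phenyl or a 2-methylphenyl on the same carbon would help to separate. They also leave open whether any other group, such as a pyridyl or a smaller alkoxy like methoxy, would keep a number close to that of compound 1.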